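A few compounds are considered here, and "the series" means these few. Any claim that something is new, unique, unknown or untested is made for them only; others in the source may bear on it.

Measured in a functional assay on MCF7 cells (Homo sapiens) for inhibition, read by colorimetric assay and MTT assay, with a stated time of 72 h; on this read-out lower numbers stand for stronger inhibition and higher numbers for weaker inhibition:
- compound 1 `Cn1c2cnc1OCCCCCCCCCOc1ccccc1-2`: 71000 nM
- compound 2 `C=CCCCCOc1cc(F)ccc1-c1cnc(OCCC=C)n1C`: 59000 nM
- compound 3 `C=CCCCCOc1cc2ccccc2cc1-c1cnc(OCCC=C)n1C`: 25000 nM

Compound 3, at 25000 nM, gives the lowest of these three numbers, and its gaps to the other two lie beyond the scatter. Compound 4 `C=CCCCCOc1cc2ccccc2cc1-c1cnc(OCCCCC=C)n1C` has but-3-en-1-yl in place of vinyl on a saturated chain carbon, two bonds along the chain from an oxygen on an aromatic ring. For the measured compounds named here, no measured pair shows this change alone, so its size is uncertain. In this assay, a small move towards a lower number is expected, possibly none beyond the scatter. The estimated step is a 1.3-fold lower number from compound 3 to compound 4 (0.10 log units; within the scatter). For compound 4 the estimate is 20000 nM, with an expected range of 9000 nM to 45000 nM.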

Compound 4, half-maximal inhibitory concentration: 37000 nM
For compound 4 the middle estimate is 1.9-fold (0.27 log units) below the measured one; low and high end bracket the measured number.
By their numbers in this assay, from the lowest: compounds 3, 4, 2 and 1 (each within the scatter of the next, the first and the last beyond it).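

For the compounds shown here, this is the first pair differing in one place: in this assay, but-3-en-1-yl in place of vinyl on a saturated chain carbon, two bonds along the chain from an oxygen on an aromatic ring, gives a 1.5-fold higher number from compound 3 to compound 4 (0.17 log units; within the scatter). At this position, then, the longer group neither clearly helps nor clearly harms. Nothing available explains this result. Still open, as far as these compounds go, is whether a saturated hexyl chain, an amine at the chain end, or a still longer chain such as oct-7-en-1-yl would move the number beyond the scatter.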